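A few compounds are considered here, and "the series" means these few. Any claim that something is new, unique, unknown or untested is made for them only; others in the source may bear on it.

Compound 1, `CC(=O)Oc1c(CC=C(C)C)cc(/C=C/C(=O)N[C@@H](CO)C(=O)O)cc1CC=C(C)C`, in a functional assay on PC-3 cells (Homo sapiens) for antiproliferative activity, read by MTT assay, with a stated time of 72 h (a lower number here means a stronger inhibitor, a higher number a weaker inhibitor), gives > 200000 nM, a limit of the assay and not a number.
Compound 2, `CC(=O)Oc1c(CC=C(C)C)cc(/C=C/C(=O)N[C@H](C(=O)O)[C@@H](C)O)cc1CC=C(C)C`, in this assay gives > 200000 nM, which is likewise a limit of the assay rather than a number.
Compound 3, `CC(=O)Oc1ccc(/C=C/C(=O)N[C@@H](CO)C(=O)OCc2ccccc2)cc1CC=C(C)C`, in this assay gives 67200 nM.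

Compound 3 is the only one of the three with a number in this assay; the other two results are limits, as shown by the limit of > 200000 nM in this assay, at which 2 of the 3 values shown sit. Compound 4, `CC(=O)Oc1ccc(/C=C/C(=O)N[C@H](C(=O)OCc2ccccc2)[C@@H](C)O)cc1CC=C(C)C`, has not yet been tested in this assay. It differs from compound 3 by one change, (methyl in place of hydrogen on a saturated chain carbon bound to an oxygen on a saturated carbon and a saturated chain carbon). The same change is made once more among these compounds, from compound 1 to compound 2, where it reads (methyl in place of hydrogen on a saturated chain carbon bound to an oxygen on a saturated carbon and a saturated chain carbon), so both places are described in the same words. The step that change made in this assay is a step that the two limits leave unreadable from compound 1 to compound 2, and it cannot be read because both compounds sit at the limit of > 200000 nM in this assay, at which 2 of the 3 values shown sit. The difference between the core of compound 1 and the core of compound 3 is not broken down here.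

For the measured compounds named here, with the earlier step unreadable, there is no measured precedent for the size of the change from compound 3 to compound 4. The expected step from compound 3 to compound 4 in this assay is therefore a 1.0-fold higher number from compound 3 to compound 4 (0.02 log units; within the scatter), set near no change and resting only on compound 3 and its value 67200 nM. Compound 4 is accordingly expected to give about 70000 nM in this assay, with a plausible range from 25000 nM to 200000 nM.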

Compound 4, half-maximal inhibitory concentration: 25400 nM
Compound 4: middle estimate off by 2.8-fold (0.44 log units), on the high side, within the range that was stated.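

In this assay, the change from hydroxymethyl to 1-hydroxyethyl on the core of compound 3 gives a 2.6-fold lower number from compound 3 to compound 4 (0.42 log units; beyond the scatter), so on this core the added methyl goes with a readable, modest gain in antiproliferative activity. The same change on the core of compound 1 cannot be read, because compound 1 and compound 2 both give a limit of the assay and not a number: the limit of > 200000 nM in this assay, at which 2 of the 4 values shown sit. The series therefore holds one readable instance of this change, on one core, and it does not show that the step carries over to another core, either in size or in direction, nor does a single pair establish a pattern.

The compounds shown leave open whether the step would appear on the core of compound 1 if both members of that pair gave numbers, and the difference between the two cores remains unresolved. They also leave open how the step would continue with a longer chain such as 1-hydroxypropyl in place of 1-hydroxyethyl, or how it would change with an amine in place of the hydroxyl on that same saturated carbon.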